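Shrinking a Para Substituent on the Shared Core

This account rests on a few compounds, and the source may have more. Where it says the series, first, only, none or still open, it means among the compounds named here.

Among the measured compounds shown here, in an assay on HepG2 cells for agonist activity at nuclear receptor subfamily 1 group I member 3 (Homo sapiens), read by a luciferase reporter, with a stated time of 23 h (a lower number here means that less compound is needed, a higher number that more compound is needed for the effect), compound 1 `CC(C)c1ccc(-c2nc3sccn3c2/C=N/OCc2ccc(Cl)c(Cl)c2)cc1` gives 590 nM, and this is the only numeric reading available for the series. For the measured compounds named here, compound 2 `Clc1ccc(CO/N=C/c2c(-c3ccc(-c4ccccc4)cc3)nc3sccn23)cc1Cl` carries a phenyl where compound 1 carries an isopropyl; in this assay compound 2 is reported as "not active" (no number reported), so no number can be placed against it, and no measured step links it to compound 1 in a way that can be counted. Compound 3 `Cc1ccc(-c2nc3sccn3c2/C=N/OCc2ccc(Cl)c(Cl)c2)cc1` keeps everything in compound 2 except that the change methyl in place of phenyl on an aromatic carbon is made, that is, methyl in place of phenyl on an aromatic carbon. Going by the values given here, with compound 2 giving no number at all, no step from it can be sized; what can be said is that compound 1, with an isopropyl at the same place, reaches a measurable value in this assay, while compound 2 does not. On that basis compound 3 is expected to return to a measurable result, but weaker than compound 1, with the estimate for compound 3 placed at 1500 nM, within a range from 400 nM to 6000 nM.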

Compound 3, half-maximal effective concentration: 490 nM
For compound 3 the middle estimate is 3.1-fold (0.49 log units) above the measured one, and the stated range covers the measured number.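

In this assay the exchange of isopropyl for methyl on the aromatic carbon gives a 1.2-fold lower number from compound 1 to compound 3 (0.08 log units; within the scatter), so the two groups cannot be told apart at this place, although methyl brings only one carbon. Phenyl is the only one of the three groups at this place that comes without a number: compound 2 is reported as not active, so the step from compound 2 to compound 3 cannot be read, while compound 3 gives a measurable reading (490 nM). The loss seen with phenyl therefore cannot be given a size, and no independent evidence bears on why the methyl and isopropyl compounds read alike while the phenyl compound gives no number.

The compounds shown leave open whether the reading holds with a plain hydrogen, a tert-butyl, a longer chain such as butyl, or a methoxy at this place. They also leave open how an amine or a carboxylic acid would read there, and whether a single ring smaller than phenyl, such as cyclopropyl, would still give a number.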